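The source may report more compounds than this note shows. Statements on the series, on what has been measured and on what is new or still open speak of the compounds shown alone.

Working notes on the series. In a functional assay on MCF7 cells (Homo sapiens) for antiproliferative activity (a higher number here means a weaker inhibitor, a lower number a stronger inhibitor), compound 1 `CO[C@@H]1[C@@H](O)[C@@H](O)[C@H](Oc2ccc3c(c2C)OC(=O)C(n2cc(-c4ccccc4)nn2)C3)OC1(C)C` gives 64400 nM, compound 2 `Cc1c(O)ccc2cc(-n3cc(/C=C/c4ccccc4)nn3)c(=O)oc12` gives 33700 nM and compound 3 `Cc1c(O)ccc2cc(-n3cc(-c4cc5ccccc5[nH]4)nn3)c(=O)oc12` gives 38300 nM. Compound 1 therefore stands within the scatter of both other compounds, and the three numbers show no separation in this assay.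

Compound 4 `CO[C@@H]1[C@@H](O)[C@@H](O)[C@H](Oc2ccc3c(c2C)OC(=O)C(n2cc(-c4c[nH]c5ccccc45)nn2)C3)OC1(C)C` keeps the core of compound 1 and changes one group: 1H-indol-3-yl in place of phenyl on an aromatic carbon. The group sits on an aromatic carbon of a five-membered aromatic ring with 3 nitrogen.

Within the data shown here, only one measured step bears on this change: a 1.1-fold higher number from compound 2 to compound 3 (0.06 log units; within the scatter), with 1H-indol-2-yl in place of 2-phenylethenyl on an aromatic carbon. That step lies within the scatter. It is indirect evidence, since compound 2 and compound 3 share a core that differs from the core of compound 1, and neither carries 1H-indol-3-yl. Among the measured compounds shown here, no measured pair compares phenyl directly with an indolyl group.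

On this evidence, no step beyond the scatter is expected in this assay, and no direction is favoured. The estimated change is a 1.4-fold lower number from compound 1 to compound 4 (0.16 log units; within the scatter). For compound 4 the expected value is 45000 nM, with an estimated range of 20000 nM to 90000 nM.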

Compound 4, half-maximal inhibitory concentration: 18300 nM
The estimate for compound 4 lay 2.5-fold (0.39 log units) above the measured number; the measured number lies below the stated range.
By their numbers in this assay, from the lowest: compounds 4, 2, 3 and 1 (each within the scatter of the next, the first and the last beyond it).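

On the core of compound 1, at the aromatic carbon of the five-membered aromatic ring with 3 nitrogen, the exchange of phenyl for 1H-indol-3-yl gives a measurable gain in this assay, with a 3.5-fold lower number from compound 1 to compound 4 (0.55 log units; beyond the scatter) as the only step shown that lies beyond the scatter. The earlier step, a 1.1-fold higher number from compound 2 to compound 3 (0.06 log units; within the scatter), sits on a different core, involves other groups and stays within the scatter, so this position responds to the group placed on it in a way those compounds could not show. The exchange adds a five-membered aromatic ring with 1 hetero atom and 1 hydrogen-bond donor, but no measurement here explains the gain.

The compounds shown leave open whether the ring nitrogen hydrogen of the indole is needed, which a 1-methylindol-3-yl group would test, or whether a second fused carbon ring alone is enough, as a naphthalen-2-yl group would test on the same core. They also leave open whether 1H-indol-2-yl on the core of compound 1 would match 1H-indol-3-yl, and whether the gain carries over to the core of compound 2.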